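Moving the hydroxyl group on a pyridine-linked phenyl ring

The source may report more compounds than this note shows. Statements on the series, on what has been measured and on what is new or still open speak of the compounds shown alone.

Measured compounds:
- Compound 1, `Oc1ccc(-c2cc(-c3ccccc3)nc(-c3ccccc3Cl)c2)cc1`: 13.6%
- Compound 2, `Oc1cccc(-c2cc(-c3ccccc3)nc(-c3cccc(Cl)c3)c2)c1`: 11.5%

Both compounds were examined in an assay on isolated protein for inhibition of DNA topoisomerase 1 (Homo sapiens), with a stated time of 30 min, tested at 100 uM; on this read-out higher numbers stand for a stronger effect at the one concentration tested and lower numbers for a weaker effect. Compound 1 gives 13.6% and compound 2 gives 11.5%; the two numbers sit within the usual scatter of each other, so neither can be called stronger or weaker, and both show only a modest effect at the single concentration tested. Compound 2 carries a 3-hydroxyphenyl group and a 3-chlorophenyl group on its shared core, while compound 1 combines a 4-hydroxyphenyl group with a 2-chlorophenyl group.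

Compound 3, `Oc1ccc(-c2cc(-c3ccccc3)nc(-c3cccc(Cl)c3)c2)cc1`, has not yet been measured. It differs from compound 2 in one place: 4-hydroxyphenyl in place of 3-hydroxyphenyl on an aromatic carbon. Among the measured compounds shown here, no pair of measured compounds differing in only this one place is available, so there is no directly comparable step to lean on. Given that compound 1 and compound 2 both return small, mutually indistinguishable numbers, compound 3 is expected to behave similarly, with a step of a number 1.5 percentage points higher from compound 2 to compound 3 (within the scatter) that stays within the scatter. Compound 3 is therefore estimated at 13%, with a likely range from 3% to 25%.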

Compound 3, a percentage reported as inhibition, at one concentration (the size of the read-out at that concentration, not a potency): 0%
Estimate against measurement, compound 3: 13 percentage points above; measured number below the stated range.
By their numbers in this assay, from the lowest: compound 3; then compounds 2 and 1 (each within the scatter of the next).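

In this assay, replacing 3-hydroxyphenyl with 4-hydroxyphenyl gives a number 11.5 percentage points lower from compound 2 to compound 3 (beyond the scatter), and replacing 2-chlorophenyl with 3-chlorophenyl gives a number 13.6 percentage points lower from compound 1 to compound 3 (beyond the scatter). Each change only relocates a group on its own ring, so the same atoms joined differently can separate these compounds, a point that the first two numbers could not show. Neither group alone goes with the low reading, as compound 1 also carries 4-hydroxyphenyl and compound 2 also carries 3-chlorophenyl, so among these three compounds the drop appears only with the two groups paired, and the data available offer no explanation for it.

Going by these compounds, the fourth pairing, 3-hydroxyphenyl with 2-chlorophenyl, remains open, as does whether the same pattern would hold if a methoxy group or an amine took the place of the hydroxyl, or if fluorine took the place of chlorine. On these data alone, with a single concentration behind every number, how these compounds would compare in potency also remains unknown.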